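The source may report more compounds than this note shows. Statements on the series, on what has been measured and on what is new or still open speak of the compounds shown alone.

Measured so far:
compound 1 `CN(/C(=N/C1CCCCC1)SCC1=CSC2=NCCN12)C1CCCCC1` gives 931 nM in a functional assay on CCRF-CEM cells for inhibition of C-X-C chemokine receptor type 4 (Homo sapiens), read by calcium flux; on this read-out higher numbers stand for weaker inhibition and lower numbers for stronger inhibition;
compound 2 `C1=C(CS/C(=N\C2CCCCC2)NC2CCCCCC2)N2CCN=C2S1` gives 6.6 nM in this assay.

Of the two numbers shown, compound 2 stands at the lower end, the stronger of the pair, and compound 1 is its only neighbour, sitting at a 140-fold lower number from compound 1 to compound 2 (2.15 log units; beyond the scatter). Among the compounds with values here, that single measured step changes the substituent on the nitrogen attached to the carbon with a double bond to nitrogen, replacing cyclohexyl(methyl)amino with cycloheptylamino, and it is the only step that touches this part of the molecule.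

Compound 3 `C1=C(CS/C(=N\C2CCCCC2)NC2CCCCCCC2)N2CCN=C2S1` is not yet measured. It differs from compound 2 by cyclooctyl in place of cycloheptyl on an amine nitrogen. The step from compound 1 to compound 2 bears on it only loosely: it altered the same nitrogen, but it removed the methyl group at the same time as it enlarged the ring, so how much of that large step belongs to ring size alone cannot be separated from these two compounds. Nothing shown tracks a change from a seven-membered to an eight-membered ring on its own.

Given this, compound 3 is expected to stay close to compound 2, with a step of about a 1.5-fold higher number from compound 2 to compound 3 (0.18 log units; within the scatter) in this assay, which may well fall within the scatter. The estimate for compound 3 is 10 nM, within a range from 3 nM to 40 nM.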

Compound 3, half-maximal inhibitory concentration: 8 nM
Beside the measured number, compound 3's estimate is 1.3-fold (0.10 log units) above it, within the range that was stated.
By their numbers in this assay, from the lowest: compounds 2 and 3 (each within the scatter of the next); then compound 1.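

In this assay, cyclooctyl in place of cycloheptyl on the amine nitrogen gives a 1.2-fold higher number from compound 2 to compound 3 (0.08 log units; within the scatter), so this position shows no measurable difference between the seven-membered and the eight-membered ring of carbon. The large step away from cyclohexyl(methyl)amino also appears with both rings: a 120-fold lower number from compound 1 to compound 3 (2.07 log units; beyond the scatter) stands alongside a 140-fold lower number from compound 1 to compound 2 (2.15 log units; beyond the scatter), and both lie beyond the scatter, so this large step is not confined to cycloheptylamino. Nothing independent of these potency numbers explains why the two rings read alike.

The compounds shown leave open how much of the large step belongs to the methyl group on that nitrogen and how much to the ring attached there, as the methyl group and the ring change together in both large steps. They also leave open whether the tolerance extends to a smaller ring such as cyclopentyl, to a larger ring such as cyclodecyl, or to an open chain such as n-octyl on the same amine nitrogen.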